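Removing the para-ethyl group from a trifluoroethoxy pyrrolinone

The source may report more compounds than this note shows. Statements on the series, on what has been measured and on what is new or still open speak of the compounds shown alone.

Compound 1 `Cc1ccc(N2C(=O)C=CC2OCC(F)(F)F)cc1` gives 9380 nM in a functional assay on HeLa cells (Homo sapiens) for inhibition; a higher number here means a weaker inhibitor, a lower number a stronger inhibitor. Compound 2 `CCc1ccc(N2C(=O)C=CC2OCC(F)(F)F)cc1` gives 6510 nM in this assay, and the step of a 1.4-fold lower number from compound 1 to compound 2 (0.16 log units; within the scatter) means the two sit within the scatter of each other. Compound 3 `O=C1C=CC(OCC(F)(F)F)N1c1ccccc1` differs from compound 2 by hydrogen in place of ethyl on an aromatic carbon. Within the data shown here, only the step from compound 1 to compound 2 touches this part of the molecule, and it was small, so the change to compound 3 is expected to be modest as well, if anything a slightly higher number. The expected step is a 1.4-fold higher number from compound 2 to compound 3 (0.14 log units; within the scatter). Compound 3 is therefore estimated at 9000 nM, with a range from 4000 nM to 20000 nM.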

Compound 3, half-maximal inhibitory concentration: > 100000 nM
Compound 3: no number, only a limit; the forecaster's own chance of this, stated with the estimate: 10%; middle value at least 11-fold (1.04 log units) from the limit.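

In this assay compound 3 gives a limit, not a number: > 100000 nM. Replacing ethyl with hydrogen gives an at least 15-fold higher number from compound 2 to compound 3 (1.18 log units; beyond the scatter), and replacing methyl with hydrogen gives an at least 10-fold higher number from compound 1 to compound 3 (1.02 log units; beyond the scatter), so here the presence of a carbon group on this aromatic carbon matters far more than the choice between methyl and ethyl. Both steps are minimum sizes, and their true sizes stay unknown because one end of each is a limit: the limit of > 100000 nM in this assay, at which 1 of the 3 values shown sits.

Going by these compounds, whether a longer chain such as propyl would give a lower number remains open. So does whether a non-carbon group, such as an amine or chlorine, could stand in for methyl or ethyl at this place.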